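Replacing the Propyl Amine Chain with a Furanylmethyl Group

The source may hold more compounds than are shown below. What is called first, only, known or untested is meant among the compounds shown, and "the series" means these compounds.

Compound 1, `CCCNc1ncnc2c1cnn2-c1ccccc1`: in a functional assay on G-361 cells (Homo sapiens) for cytotoxicity, read by sulforhodamine B assay (a higher number here means a weaker inhibitor of growth, a lower number a stronger inhibitor of growth), compound 1 gives > 100000 nM, which is a limit of the assay and not a number.
Compound 2, `CCCNc1nc(C)nc2c1cnn2-c1ccccc1`: in this assay compound 2 gives 36000 nM.
Compound 3, `CCCNc1nc(CC)nc2c1cnn2-c1ccccc1`: in this assay compound 3 gives 2200 nM.

Among the measured compounds shown here, compound 3 holds the lowest of the two numbers measured so far; its nearest neighbour is compound 2, with a 16-fold lower number from compound 2 to compound 3 (1.21 log units; beyond the scatter). The two other steps, an at least 2.7-fold lower number from compound 1 to compound 2 (0.44 log units; beyond the scatter) and an at least 45-fold lower number from compound 1 to compound 3 (1.65 log units; beyond the scatter), start from a value that sits at the limit of > 100000 nM in this assay, at which 1 of the 3 values shown sits. All three steps change the group on an aromatic carbon of the shared core and leave the propylamino side alone.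

Compound 4, `CCc1nc(NCc2ccco2)c2cnn(-c3ccccc3)c2n1`, differs from compound 3 in that other part: furan-2-yl in place of ethyl on a saturated chain carbon bound to a nitrogen on an aromatic ring. For the measured compounds named here, no measured step touches this place, so the three steps above give no direct guide to direction or size. The ethyl on the aromatic carbon, present in compound 3, is kept in compound 4. With nothing pointing either way, the expectation is a step within the scatter, a 1.1-fold higher number from compound 3 to compound 4 (0.06 log units; within the scatter), while a change of this extent could still move the number in either direction. The estimate for compound 4 in this assay is therefore 2500 nM, with a range from 500 nM to 15000 nM.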

Compound 4, concentration for 50% growth inhibition: 2040 nM
Estimate against measurement, compound 4: 1.2-fold (0.09 log units) above; the range from low to high includes it.
By their numbers in this assay, from the lowest: compounds 4 and 3 (each within the scatter of the next); then compound 2. At a limit, above all of these: compound 1.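

In this assay, among the compounds shown here, the first change at the amine side of the molecule gives a 1.1-fold lower number from compound 3 to compound 4 (0.03 log units; within the scatter), so this place accepts furan-2-yl in place of ethyl on a saturated chain carbon bound to a nitrogen on an aromatic ring without a reading beyond the scatter. For the compounds shown here, all the earlier steps changed the group on the aromatic carbon and moved the number beyond the scatter, whereas this swap of a propyl chain for a (furan-2-yl)methyl group brings in a five-membered aromatic ring and a hydrogen-bond acceptor, and compound 3 and compound 4 still read alike, which shows that the propyl chain itself is not essential when the ethyl on the aromatic carbon is kept. Nothing in the data at hand explains why these two quite different groups give matching numbers.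

Still open, as far as these compounds go, is whether the (furan-2-yl)methyl group would read the same with the hydrogen of compound 1 or the methyl of compound 2 on the aromatic carbon. Also open, from the compounds shown here alone, is how a benzyl group, or a chain ending in an amine or a carboxylic acid, would fare at this same place.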